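The compounds below may be only part of what the source reports. "The series", "measured", "known", "first", "only" and "open" are said of these compounds alone.

Measured compounds:
compound 1, `CO[C@]1(C(=O)N2CC[C@](c3ccc(C(F)(C(F)(F)F)C(F)(F)F)cc3)(S(=O)(=O)c3ccc(F)cc3)C2)CC[C@H](C(=O)O)CC1`, 95%
compound 2, `O=C(O)[C@H]1CC[C@](F)(C(=O)N2CC[C@](c3ccc(C(F)(C(F)(F)F)C(F)(F)F)cc3)(S(=O)(=O)c3ccc(F)cc3)C2)CC1`, "not determined" (no result reported)

In an ADME assay on microsomes from liver (Mus musculus) for metabolic stability, with a stated time of 10 min (on this read-out lower numbers stand for a less stable compound and higher numbers for a more stable compound), compound 1 gives 95%, close to the top of the scale. Compound 2 was not measured in this assay, so it has no number of its own to stand on; the only measured point in this small set is compound 1. Compound 3 is `O=C([C@H]1CC[C@H](CO)CC1)N1CC[C@](c2ccc(C(F)(C(F)(F)F)C(F)(F)F)cc2)(S(=O)(=O)c2ccc(F)cc2)C1`. The change from compound 2 to compound 3 is 4-(hydroxymethyl)cyclohexyl in place of 4-carboxy-1-fluorocyclohexyl on a carbonyl carbon. For the measured compounds named here, no measured pair shows a step of this kind, so its size can only be guessed. The expectation is a moderate drop in this assay, somewhat beyond the usual scatter, because compound 1 already stands at 95% and leaves little room upward. Compound 3 is therefore expected to give about 70%, with a likely range from 40% to 95%.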

Compound 3, percent of the compound remaining: 63%
The estimate for compound 3 lay 7 percentage points above the measured number, and the stated range covers the measured number.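

In this assay, 4-(hydroxymethyl)cyclohexyl in place of 4-carboxy-1-methoxycyclohexyl on the carbonyl carbon gives a number 32 percentage points lower from compound 1 to compound 3 (beyond the scatter). This first readable step shows that the group on this carbonyl carbon can shift the read-out substantially while the rest of the molecule stays the same, although the swap removes the carboxy and methoxy groups together and so cannot show which loss matters. No measurement here explains why the number falls.

Steps involving compound 2 cannot be read, so what 4-carboxy-1-fluorocyclohexyl does at this position remains unknown. For the compounds shown here, also open is how a group carrying only one of the changes would behave, such as 4-carboxycyclohexyl, with its carboxylic acid but no methoxy, or 4-(hydroxymethyl)-1-methoxycyclohexyl, with its methoxy but no carboxylic acid.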